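Swapping the Aryl Group on the Core of Compound 2

The source may hold more compounds than are shown below. What is called first, only, known or untested is meant among the compounds shown, and "the series" means these compounds.

Compound 2 `CS(=O)(=O)Nc1cccc(-c2cc(C(O)(C(F)(F)F)C(F)(F)F)cnc2N2CCN(S(=O)(=O)c3ccc(N)nc3)CC2)c1` carries a 3-(methanesulfonamido)phenyl group on the shared core. Going by the values given here, in an ADME assay (liver) for metabolic stability, with Liver microsome (Homo sapiens) as the target, using microsomes and NADPH, with a stated time of 30 min, tested at 1 uM (a lower number here means slower removal, a higher number faster removal of the compound), compound 2 gives 40 mL.min-1.g-1, the highest of the two numbers measured so far. Among the compounds with values here, its only neighbour is compound 1 `Cn1cc(-c2cc(C(O)(C(F)(F)F)C(F)(F)F)cnc2N2CCN(S(=O)(=O)c3ccc(N)nc3)CC2)cn1`, which bears a 1-methyl-1H-pyrazol-4-yl group in the same place and in this assay gives 19 mL.min-1.g-1; the step of a 2.1-fold higher number from compound 1 to compound 2 (0.32 log units; beyond the scatter) is the one measured change at this position. Compound 3 `Nc1ccc(S(=O)(=O)N2CCN(c3ncc(C(O)(C(F)(F)F)C(F)(F)F)cc3-c3ccc4scnc4c3)CC2)cn1` differs from compound 2 in this way: 1,3-benzothiazol-5-yl in place of 3-(methanesulfonamido)phenyl on an aromatic carbon. Within the data shown here, no measured step covers this exact exchange, and the earlier step shows only that changing the group at this place can move the number modestly. For compound 3 the expected step is a 1.1-fold higher number from compound 2 to compound 3 (0.05 log units; within the scatter), with wide uncertainty. Compound 3 is estimated to give about 45 mL.min-1.g-1 in this assay, between 20 mL.min-1.g-1 and 100 mL.min-1.g-1.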

Compound 3, intrinsic clearance in microsomes: 39 mL.min-1.g-1
For compound 3 the middle estimate is 1.2-fold (0.06 log units) above the measured one; low and high end bracket the measured number.
By their numbers in this assay, from the lowest: compound 1; then compounds 3 and 2 (each within the scatter of the next).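

In this assay the exchange at this position gives a 1.0-fold lower number from compound 2 to compound 3 (0.01 log units; within the scatter) even though the two groups are built differently: 3-(methanesulfonamido)phenyl has one aromatic ring and one hydrogen-bond donor, while 1,3-benzothiazol-5-yl has two aromatic rings and no hydrogen-bond donors. Against the 1-methyl-1H-pyrazol-4-yl group the same new group gives a 2.1-fold higher number from compound 1 to compound 3 (0.31 log units; beyond the scatter) and so joins 3-(methanesulfonamido)phenyl on the same side, which leaves compound 1 as the only one of the three with the lower number. Nothing measured here explains why the numbers fall this way.

Going by these compounds, whether a group with no aromatic ring at this place, such as an amine or a short alkyl chain, would keep the number near that of compound 1 stays open. So does whether a carboxylic acid on the phenyl ring would shift it in either direction.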